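Methyl in place of hydrogen on the core of compound 2

The compounds below may be only part of what the source reports. "The series", "measured", "known", "first", "only" and "open" are said of these compounds alone.

Measured so far in a functional assay on MCF7 cells (Homo sapiens) for cytotoxicity, read by MTT assay, with a stated time of 72 h; on this read-out lower numbers stand for stronger inhibition and higher numbers for weaker inhibition:
compound 1 `Cc1ccc2[nH]c(-c3ccc[nH]3)c(C3CC(=O)NC3=O)c2c1` gives 29000 nM.
compound 3 `COc1ccc2[nH]c(-c3ccc[nH]3)cc2c1` gives 84000 nM.
compound 2 `c1ccc2[nH]c(-n3cccn3)cc2c1` gives only a limit, > 100000 nM.

Compound 2 thus sits at the limit of > 100000 nM in this assay, at which 1 of the 3 values shown sits; no number is known for it, only that it lies at the limit. Compound 4 `Cc1ccc2[nH]c(-n3cccn3)cc2c1` differs from compound 2 by methyl in place of hydrogen on an aromatic carbon. Among the compounds with values here, no measured pair shows the effect of this change by itself, so there is nothing to set its size. With a small, non-polar group entering, the expected step in this assay is none beyond the scatter, and a step that the limit leaves unreadable from compound 2 to compound 4 is therefore expected to be close to flat. Compound 4 is estimated at about 120000 nM in this assay, within 50000 nM to 300000 nM, and most likely again reported only as a limit.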

Compound 4, half-maximal inhibitory concentration: > 100000 nM
Compound 4: only a limit was reported; the forecaster's own chance of this, stated with the estimate: 70%; the middle value lies beyond the limit too.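

No step can be read between compound 2 and compound 4, because both are reported only as limits: the limit of > 100000 nM in this assay, at which 2 of the 4 values shown sit.

The compounds shown leave open what methyl in place of hydrogen on an aromatic carbon does by itself.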